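Methyl for methoxy on a dicyanoethenyl compound

This account rests on a few compounds, and the source may have more. Where it says the series, first, only, none or still open, it means among the compounds named here.

In a functional assay on MCF7 cells (Homo sapiens) for antiproliferative activity, with a stated time of 5 days (a higher number here means a weaker inhibitor, a lower number a stronger inhibitor), compound 1 `COc1ccc(-c2[nH]c3ccc(OC)cc3c2C=O)cc1` gives 180 nM as its half-maximal inhibitory concentration. Compound 2 `COc1ccc(-c2[nH]c3ccc(OC)cc3c2C=C(C#N)C#N)cc1` gives 340 nM on the same read-out. Compound 3 `COc1ccc(-c2[nH]c3cc(OC)ccc3c2C=C(C#N)C#N)cc1` gives 300 nM with the same groups placed differently on the core. Compound 2 therefore cannot be separated from either neighbour: compound 3 lies nearest to it and compound 1 furthest, and both gaps stay within the scatter.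

Compound 4 `COc1ccc(-c2[nH]c3ccc(C)cc3c2C=C(C#N)C#N)cc1` has not yet been measured. It carries methyl in place of methoxy on an aromatic carbon of compound 2 methyl in place of methoxy on an aromatic carbon and is otherwise unchanged. Within the data shown here, only one measured step bears on this change, and only indirectly: a 1.9-fold higher number from compound 1 to compound 2 (0.28 log units; within the scatter) with 2,2-dicyanoethenyl in place of formyl on an aromatic carbon. That step concerns a different group and stays within the scatter. Among the measured compounds shown here, no measured pair exchanges methoxy for methyl, so the size of this step has no direct precedent here. With all three values lying close together, no step beyond the scatter is expected in this assay for this exchange. The estimate amounts to an expected step of a 1.2-fold higher number from compound 2 to compound 4 (0.07 log units; within the scatter) with no firm direction implied. Compound 4 is estimated at 400 nM with an expected range from 150 nM to 1100 nM as its upper end.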

Compound 4, half-maximal inhibitory concentration: 200 nM
Estimate against measurement, compound 4: 2.0-fold (0.30 log units) above; measured number inside the range.
By their numbers in this assay, from the lowest: compounds 1, 4, 3 and 2 (each within the scatter of the next).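

In this assay, among these compounds, the exchange of methoxy for methyl gives a 1.7-fold lower number from compound 2 to compound 4 (0.23 log units; within the scatter), which is the first direct reading of this change. The step shows that, on a compound carrying 2,2-dicyanoethenyl, the methoxy on this aromatic carbon, meta to a fused ring and para to a fused ring, can give way to methyl, with one heavy atom fewer and one hydrogen-bond acceptor fewer, without moving the number beyond the scatter. No measured property of either group is available to account for this result, so the reading rests on the values alone.

The compounds shown leave open whether a group of another kind at this carbon, such as an amine, a carboxylic acid or a longer chain, would produce a step beyond the scatter. Among the compounds shown here, they also leave open whether methyl in place of methoxy would read the same way on the formyl compound, compound 1, where this exchange has no printed step.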